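Bromo Versus Dichloro at the Aryl Position of a Fused Core

The compounds below may be only part of what the source reports. "The series", "measured", "known", "first", "only" and "open" are said of these compounds alone.

Measured compounds:
- Compound 1, `Cc1ccc(-c2csc3nc(-c4cc(F)c(Cl)cc4Cl)nn23)cc1`: 0%
- Compound 2, `Fc1cc(-c2nc3scc(-c4ccc(Br)cc4)n3n2)c(Cl)cc1Cl`: 25%

Of the compounds shown here, two have been measured in a functional assay on the whole organism (strain Wister albino) for inhibition, with Rattus norvegicus as the target, read by paw edema, with stated times of 30 min and 3 h, at a dose of 50 mg/kg by the oral route; on this read-out lower numbers stand for less inhibition and higher numbers for more inhibition at the one dose given (going by the name of the read-out). Compound 1 gives 0%, and compound 2 gives 25%. Going by the values given here, the only single-point step measured so far is a number 25 percentage points higher from compound 1 to compound 2 (beyond the scatter). On these two numbers compound 2 stands highest, with compound 1 the nearest neighbour and a number beyond the scatter below it.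

Compound 3, `Fc1cc(-c2nc3scc(-c4ccc(Cl)cc4Cl)n3n2)c(Cl)cc1Cl`, has not yet been measured. It differs from compound 2 by 2,4-dichlorophenyl in place of 4-bromophenyl on an aromatic carbon. Among the compounds with values here, no measured step exchanges one halogenated phenyl group for another, so the one step known, a halogen entering in place of methyl in a number 25 percentage points higher from compound 1 to compound 2 (beyond the scatter), bears on the new change only indirectly: it shows that this aryl position can move the read-out by a modest amount. With both compound 2 and compound 3 carrying halogenated phenyl rings at that position, compound 3 is expected to remain close to compound 2, with the step of no change at the digits printed from compound 2 to compound 3 (within the scatter) not expected to pass beyond the scatter. Compound 3 is therefore estimated at 25%, within a range of 5% to 45%.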

Compound 3, a percentage reported as inhibition, in the whole organism at one dose (the size of the read-out at that dose, not a potency): 17.2%
Beside the measured number, compound 3's estimate is 7.8 percentage points above it, within the range that was stated.
By their numbers in this assay, from the lowest: compound 1; then compounds 3 and 2 (each within the scatter of the next).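

In this assay, 2,4-dichlorophenyl in place of 4-bromophenyl on this aromatic carbon, next to the ring nitrogen and two ring bonds from the ring sulfur, gives a number 7.8 percentage points lower from compound 2 to compound 3 (within the scatter), so this read-out does not separate these two halogenated phenyl groups, although they differ in the halogen and in the number of halogens they carry. The exchange of 4-methylphenyl for 2,4-dichlorophenyl gives a number 17.2 percentage points higher from compound 1 to compound 3 (beyond the scatter), which shows that the earlier separation from the methyl compound was not confined to 4-bromophenyl and now holds for two halogenated phenyl groups at this position. Nothing beyond the read-out itself is available to explain either step.

The compounds shown leave open how this position responds to groups other than methyl, bromo and chloro on the phenyl ring, such as an amine, a carboxylic acid or a methoxy group, and whether any of them would carry the read-out further than the halogens do. They also leave open what the fluoro- and chloro-bearing phenyl ring contributes, since it stays the same throughout, and whether these differences hold at other oral doses.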